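The compounds below may be only part of what the source reports. "The series", "measured", "known", "first", "only" and "open" are said of these compounds alone.

Compound 1 `CCCSc1nc(N/N=C/c2ccccc2F)c2nnn(Cc3ccccc3)c2n1`: in a functional assay on ECa-109 cells (Homo sapiens) for antiproliferative activity, read by MTT assay, with a stated time of 72 h (on this read-out lower numbers stand for stronger inhibition and higher numbers for weaker inhibition), compound 1 reaches only the assay limit, > 64000 nM.
Compound 2 `CCCSc1nc(N/N=C/c2ccc(Cl)cc2)c2nnn(Cc3ccccc3)c2n1`: in this assay compound 2 likewise reaches only the assay limit, > 64000 nM.
Compound 3 `CCCSc1nc(N/N=C(\C)c2ccc(Br)cc2)c2nnn(Cc3ccccc3)c2n1`: in this assay compound 3 gives 4670 nM.

Compound 3 is thus the only one of the three with an actual number; the other two values are limits (the limit of > 64000 nM in this assay, at which 2 of the 3 values shown sit). The step to compound 4 `CCCSc1nc(N/N=C(\C)c2ccccc2O)c2nnn(Cc3ccccc3)c2n1` keeps the methyl-bearing carbon of compound 3 and changes only the aromatic ring hung on it: 2-hydroxyphenyl in place of 4-bromophenyl on a carbon with a double bond to nitrogen.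

Among the compounds with values here, two measured steps touch the same region, an at least 13-fold lower number from compound 1 to compound 3 (1.13 log units; beyond the scatter) and an at least 13-fold lower number from compound 2 to compound 3 (1.13 log units; beyond the scatter), but each of them swapped the aromatic ring and added the methyl at the same time, so the ring swap on its own is not isolated, and both start from a limit. The step that the two limits leave unreadable from compound 1 to compound 2 compares two halogen-bearing rings and cannot be read. Within the data shown here, no measured step replaces a halogen with a hydroxyl group, so the present change has no direct precedent.

The expectation for compound 4 is therefore a modest step, a 1.9-fold higher number from compound 3 to compound 4 (0.28 log units; within the scatter), leaning toward a weaker result, and compound 4 is estimated at 9000 nM, within 2000 nM to 40000 nM.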

Compound 4, half-maximal inhibitory concentration: 11100 nM
Beside the measured number, compound 4's estimate is 1.2-fold (0.09 log units) below it, within the range that was stated.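

In this assay, within the data shown here, the result gives the first step with a real number at both ends, and it changes only the ring on the methyl-bearing carbon: a 2.4-fold higher number from compound 3 to compound 4 (0.38 log units; beyond the scatter). This shows that the ring at this position does affect the read-out, although 2-hydroxyphenyl in place of 4-bromophenyl gives only a modest loss, and compound 4 still yields a number rather than a limit. The other two steps, an at least 5.7-fold lower number from compound 2 to compound 4 (0.76 log units; beyond the scatter) and an at least 5.7-fold lower number from compound 1 to compound 4 (0.76 log units; beyond the scatter), start from a limit and change the ring and add the methyl together, so they show that a second methyl-bearing compound gives a lower number than either compound without that methyl, but they do not show which of the two changes is responsible.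

Steps between compound 1 and compound 2 cannot be read, as both compounds sit at a limit: the limit of > 64000 nM in this assay, at which 2 of the 4 values shown sit.

No pair shown isolates the methyl, and the swap from compound 3 to compound 4 changes both the atom on the ring and its place, leaving open how 4-hydroxyphenyl, 2-bromophenyl or an ethyl group on that carbon would read.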